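Cyanomethyl in place of 3-cyanobenzyl on the sulfonamide nitrogen

The source may report more compounds than this note shows. Statements on the series, on what has been measured and on what is new or still open speak of the compounds shown alone.

Measured compounds:
compound 1 `N#Cc1cccc(CN2c3ccsc3C(=O)N(Cc3ccccc3)S2(=O)=O)c1`, > 305000 nM
compound 2 `O=C1c2sccc2N(Cc2ccc(Cl)cc2Cl)S(=O)(=O)N1Cc1ccccc1`, 247000 nM
compound 3 `N#Cc1ccc(CN2c3ccsc3C(=O)N(Cc3ccccc3)S2(=O)=O)cc1`, 8500 nM

In an ADME assay on MT4 cells (Homo sapiens) for cytotoxicity, read by MTT assay, with a stated time of 4 days (on this read-out higher numbers stand for lower toxicity in this test and lower numbers for higher toxicity in this test), compound 1 gives > 305000 nM, which is a limit of the assay and not a number. That is the limit of > 305000 nM in this assay, at which 1 of the 3 values shown sits, so compound 1 stands only at the edge of what this assay can report. Compound 2 gives 247000 nM, and compound 3 gives 8500 nM.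

Compound 4 `N#CCN1c2ccsc2C(=O)N(Cc2ccccc2)S1(=O)=O` differs from compound 1 in one place: cyano in place of 3-cyanophenyl on a saturated chain carbon bound to a sulfonamide nitrogen in a ring. For the measured compounds named here, none of the measured steps makes the same kind of change; each of them swaps one six-membered aromatic ring for another on that carbon. The step of an at least 1.2-fold lower number from compound 1 to compound 2 (0.09 log units; that floor lies within the scatter) stays within the scatter, whereas the steps of an at least 35-fold lower number from compound 1 to compound 3 (1.55 log units; beyond the scatter) and a 29-fold lower number from compound 2 to compound 3 (1.46 log units; beyond the scatter) are large. The change to compound 4 removes the ring altogether and leaves a cyano on the chain carbon, a move for which the measured series gives no direct guide.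

Compound 4 is therefore expected to sit near compound 1 in this assay, with the step of an at least 1.2-fold lower number from compound 1 to compound 4 (0.08 log units; that floor lies within the scatter) estimated to be modest and uncertain in direction. The estimate for compound 4 is 250000 nM, within the range 60000 nM to 400000 nM.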

Compound 4, half-maximal cytotoxic concentration: 5700 nM
The estimate for compound 4 lay 44-fold (1.64 log units) above the measured number; the whole stated range lies above it.
By their numbers in this assay, from the lowest: compounds 4 and 3 (each within the scatter of the next); then compound 2. At a limit, above all of these: compound 1.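

In this assay, the earlier compounds had shown large steps only between aromatic rings on this chain carbon; cyano in place of 3-cyanophenyl takes the ring away and gives an at least 53-fold lower number from compound 1 to compound 4 (1.72 log units; beyond the scatter), so a low number at this position does not depend on a six-membered aromatic ring being there. Set against 4-cyanophenyl, the change to cyano gives a 1.5-fold lower number from compound 3 to compound 4 (0.17 log units; within the scatter), while against 2,4-dichlorophenyl it gives a 43-fold lower number from compound 2 to compound 4 (1.64 log units; beyond the scatter), so the group without a ring falls with the 4-cyanophenyl compound and apart from the other two. The step from 3-cyanophenyl to cyano can be read only as a floor, because compound 1 stands at a limit of the assay and not at a number: the limit of > 305000 nM in this assay, at which 1 of the 4 values shown sits.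

The compounds leave open why 3-cyanophenyl and 4-cyanophenyl read so differently when cyano alone reads like the latter, and a nitrile is present in all three. Going by these compounds, they also leave open whether the nitrile itself matters here, as a plain methyl, a longer chain ending in a nitrile or a carboxylic acid on this carbon would read in this assay is unknown.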